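Notes on the ring substituent of the shared core

The source may hold more compounds than are shown below. What is called first, only, known or untested is meant among the compounds shown, and "the series" means these compounds.

Measured so far:
compound 1: `COc1ccc(S(=O)(=O)NC(=O)Nc2ccc(Cl)cc2)s1` — 100%
compound 2: `CCOc1ccc(S(=O)(=O)NC(=O)Nc2ccc(Cl)cc2)s1` — 96%

On the numbers shown, compound 1 gives 100% in a functional assay on the whole organism (6C3HED cells, Mus musculus) for inhibition, at a dose of 300 mg/kg by the oral route; on this read-out higher numbers stand for more inhibition at the one dose given (going by the name of the read-out) and lower numbers for less inhibition. For the measured compounds named here, the only other point is compound 2 with 96%, and the step of a number 4 percentage points lower from compound 1 to compound 2 (within the scatter) lies within the scatter, so the two compounds cannot be told apart on this read-out. The series therefore offers no step beyond the scatter at all, and the read-out of compound 1 sits at the top of what the assay can report.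

Compound 3, `CC(C)c1ccc(S(=O)(=O)NC(=O)Nc2ccc(Cl)cc2)s1`, has not been measured. It differs from compound 1 in one place: isopropyl in place of methoxy on an aromatic carbon. Going by the values given here, no measured step replaces a methoxy by an isopropyl. Among the compounds with values here, the only step on record at this position, from compound 1 to compound 2, lengthens the chain bound to the ring oxygen and stays within the scatter. It bears on compound 3 only loosely, since here the oxygen leaves altogether. With no step beyond the scatter to lean on, a small downward step at most is expected in this assay.

Compound 3 is thus estimated at 88% in this assay, within 62% to 100%. The estimated step is a number 12 percentage points lower from compound 1 to compound 3 (beyond the scatter).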

Compound 3, a percentage reported as inhibition, in the whole organism at one dose (the size of the read-out at that dose, not a potency): 63%
Beside the measured number, compound 3's estimate is 25 percentage points above it; low and high end bracket the measured number.
By their numbers in this assay, from the lowest: compound 3; then compounds 2 and 1 (each within the scatter of the next).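

In this assay, this place on the five-membered aromatic ring, next to the ring sulfur, proves sensitive to the group it carries: isopropyl in place of methoxy gives a number 37 percentage points lower from compound 1 to compound 3 (beyond the scatter), and isopropyl in place of ethoxy gives a number 33 percentage points lower from compound 2 to compound 3 (beyond the scatter). The earlier compounds shown here showed only that the chain on the ring oxygen can be lengthened with a number 4 percentage points lower from compound 1 to compound 2 (within the scatter), whereas these two steps show that exchanging either oxygen-linked group for isopropyl does not leave the read-out intact. Nothing at hand bears on the reason for these steps.

The compounds shown do not separate the departure of the oxygen from the branching of the group, and an isopropoxy group or a straight propyl chain at this place would speak to that. Also open, from the compounds shown here alone, is how this place responds to groups of another kind, such as an amine or a carboxylic acid, and whether the same steps appear at doses other than the single one used here.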